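This account rests on a few compounds, and the source may have more. Where it says the series, first, only, none or still open, it means among the compounds named here.

Compound 1 `Cc1ccc(Nc2nc(C)c(C(=O)/C=C/c3ccccc3)s2)cc1`: > 25000 nM
Compound 2 `Cc1ccccc1Nc1nc(C)c(C(=O)/C=C/c2ccccc2)s1`: > 25000 nM

In a functional assay on BGC-823 cells (Homo sapiens) for cytotoxicity, read by MTT assay (on this read-out higher numbers stand for weaker inhibition and lower numbers for stronger inhibition), compound 1 gives only a limit, > 25000 nM. In this assay compound 2 likewise gives only a limit, > 25000 nM. Compound 2 thus stands at the limit of > 25000 nM in this assay, at which 2 of the 2 values shown sit, and no number separates it from the other compound shown. The step that the two limits leave unreadable from compound 1 to compound 2 cannot be read, since both values are limits. Compound 3 `Cc1cccc(Nc2nc(C)c(C(=O)/C=C/c3ccccc3)s2)c1` differs from compound 2 by 3-methylphenyl in place of 2-methylphenyl on a nitrogen on an aromatic ring. Among the measured compounds shown here, the single measured step, which put 2-methylphenyl in place of 4-methylphenyl on the same nitrogen, gave no readable size and so offers no direction for this assay. Compound 3 is therefore expected to stay at the limit as well, with an expected step that the limit leaves unreadable from compound 2 to compound 3 not beyond the scatter. The estimate for compound 3 is 30000 nM, expected between 12000 nM and 80000 nM.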

Compound 3, half-maximal inhibitory concentration: 13600 nM
Compound 3: the middle estimate sits 2.2-fold (0.34 log units) above what was measured; the measured number falls inside the stated range.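

In this assay, among the compounds shown here, 3-methylphenyl on the nitrogen is the first of these groups to give a number and not a limit, which shows that this position can yield a readable value. As far as these compounds go, putting it in place of 2-methylphenyl gives an at least 1.8-fold lower number from compound 2 to compound 3 (0.26 log units; that floor lies within the scatter), and putting it in place of 4-methylphenyl gives an at least 1.8-fold lower number from compound 1 to compound 3 (0.26 log units; that floor lies within the scatter); each is only a floor, so the true size of either step remains unknown. Compound 1 and compound 2 remain at a limit: the limit of > 25000 nM in this assay, at which 2 of the 3 values shown sit.

The compounds shown leave open whether the methyl itself matters, or whether 3-chlorophenyl, 3-methoxyphenyl or 3-ethylphenyl on the same nitrogen would also give a number. They also leave open how unsubstituted phenyl or a carboxylic acid on that ring would read in this assay.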